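Amine demethylation at two positions in the series

The source may hold more compounds than are shown below. What is called first, only, known or untested is meant among the compounds shown, and "the series" means these compounds.

Compound 2 `CN[C@@H](CC(C)C)CN(C(=O)[C@@H]1C[C@H]1c1ccccc1)c1ccc(-c2ccccc2)cc1` gives 2 nM in a functional assay for agonist activity at G protein-coupled receptor 88 (Homo sapiens), read by HTRF and cAMP accumulation; a higher number here means that more compound is needed for the effect, a lower number that less compound is needed. Compound 1 `CC(C)C[C@H](N)CN(C(=O)[C@@H]1C[C@H]1c1ccccc1)c1ccc(-c2ccccc2)cc1` differs from it by hydrogen in place of methyl on an amine nitrogen, and in this assay compound 1 gives 880 nM; the step is a 440-fold higher number from compound 2 to compound 1 (2.64 log units; beyond the scatter). Compound 3 `CC[C@H](C)[C@H](N)CN(C(=O)[C@@H]1C[C@H]1c1ccccc1)c1ccc(-c2ccc(CN(C)C)cc2)cc1` has a core that differs from that of compound 2 in a way not broken down here. In this assay compound 3 gives 460 nM, a value lying within the scatter of that of compound 1. Compound 4 `CC[C@H](C)[C@H](N)CN(C(=O)[C@@H]1C[C@H]1c1ccccc1)c1ccc(-c2ccc(CNC)cc2)cc1` is not yet measured; it differs from compound 3 by hydrogen in place of methyl on an amine nitrogen. This is the same kind of change as that from compound 2 to compound 1, not the same: there the amine nitrogen had one saturated chain carbon as its other neighbour, here it has two, within the (dimethylamino)methyl group. Within the data shown here, the earlier step was large, but no measured pair shows what the amine nitrogen of the (dimethylamino)methyl group tolerates, so the earlier step is a weak guide. The step of a 1.2-fold lower number from compound 3 to compound 4 (0.06 log units; within the scatter) is expected to be small, within the scatter. Compound 4 is estimated at 400 nM, with a range from 120 nM to 1400 nM.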

Compound 4, half-maximal effective concentration: 6400 nM
Estimate against measurement, compound 4: 16-fold (1.20 log units) below, and the stated range ends below it.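

In this assay, hydrogen in place of methyl on the amine nitrogen of the (dimethylamino)methyl group gives a 14-fold higher number from compound 3 to compound 4 (1.14 log units; beyond the scatter). The change therefore moves the number the same way in both measured pairs, but its size does not carry over from one core to the other: the same change on two cores in this assay, a 440-fold higher number (2.64 log units; beyond the scatter) from compound 2 to compound 1 and a 14-fold higher number (1.14 log units; beyond the scatter) from compound 3 to compound 4, 32-fold (1.50 log units) apart, beyond the scatter of two such steps

These two pairs do not show what sets the size, since the change sits on a different amine nitrogen in each pair and the two cores differ in more than one place, and two pairs make no rule for the wider series.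

Still open, as far as these compounds go, is what the unsubstituted aminomethyl group, with both methyls gone, or a longer chain such as ethyl on that nitrogen would give on the core of compound 3. Also open, from the compounds shown here alone, is whether a methyl on the other amine nitrogen of compound 3, the one on the chain, would shift the number as it does between the first two compounds.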